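Fluorines for methoxy on the cyclopropyl aryl of compound 3

A few compounds are considered here, and "the series" means these few. Any claim that something is new, unique, unknown or untested is made for them only; others in the source may bear on it.

Measured compounds:
compound 1, `CC(C)C[C@H](N)CN(C(=O)[C@@H]1C[C@H]1c1ccccc1)c1ccc(-c2ccccc2)cc1`: 880 nM in a functional assay for agonist activity at G protein-coupled receptor 88 (Homo sapiens), read by HTRF and cAMP accumulation; on this read-out higher numbers stand for an effect only at larger amounts of compound and lower numbers for an effect already at smaller amounts
compound 2, `N[C@H](CN(C(=O)[C@@H]1C[C@H]1c1ccccc1)c1ccc(-c2ccccc2)cc1)C1CCCCC1`: 0.66 nM in this assay
compound 3, `CC[C@H](C)[C@H](N)CN(C(=O)[C@@H]1C[C@H]1c1ccc(OC)cc1)c1ccc(-c2ccccc2)cc1`: in this assay compound 3 reaches only the limit > 25000 nM, not a number.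

Compound 3 therefore stands at the edge of what this assay can report, (the limit of > 25000 nM in this assay, at which 1 of the 3 values shown sits). Compound 4 `CC[C@H](C)[C@H](N)CN(C(=O)[C@@H]1C[C@H]1c1ccc(F)c(F)c1)c1ccc(-c2ccccc2)cc1` differs from it by 3,4-difluorophenyl in place of 4-methoxyphenyl on a saturated ring carbon. Within the data shown here, the only measured step, a 1300-fold lower number from compound 1 to compound 2 (3.12 log units; beyond the scatter), concerns a different place, the chain carbon carrying the amine, and does not bear on the aryl change; compounds 1 and 2 carry an unsubstituted phenyl on the cyclopropane. Among the measured compounds shown here, no measured step touches the aryl substituent, so neither direction nor size can be read from the data. Compound 4 is estimated at 8000 nM, with a range from 500 nM to 25000 nM. That corresponds to an expected at least 3.1-fold lower number from compound 3 to compound 4 (0.49 log units; beyond the scatter).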

Compound 4, half-maximal effective concentration: 720 nM
Compound 4: the middle estimate sits 11-fold (1.05 log units) above what was measured; the range from low to high includes it.
By their numbers in this assay, from the lowest: compound 2; then compounds 4 and 1 (each within the scatter of the next). At a limit, above all of these: compound 3.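

In this assay, among these compounds, the aryl group on this saturated ring carbon turns out to matter, which the earlier compounds could not show, as none of their steps touched it: 3,4-difluorophenyl in place of 4-methoxyphenyl gives an at least 34-fold lower number from compound 3 to compound 4 (1.54 log units; beyond the scatter). Compound 3 stands at a limit of the assay, not at a number: the limit of > 25000 nM in this assay, at which 1 of the 4 values shown sits. The compounds shown leave open whether a single fluorine or a chlorine at this place would do the same on the shared core of compound 3 and compound 4. Also open, as far as these compounds go, is how 3,4-difluorophenyl behaves alongside the cyclohexyl group of compound 2.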